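The source may hold more compounds than are shown below. What is called first, only, known or untested is meant among the compounds shown, and "the series" means these compounds.

Compound 1 `COc1cc(-c2nc3ccc(C)cn3c2NC2CCCCC2)ccc1OCCCNC(=O)Nc1ccc(C(F)(F)F)cc1` gives 439 nM in an assay for inhibition of Polyunsaturated fatty acid 5-lipoxygenase (Homo sapiens), read by HPLC, with a stated time of 15 min; a higher number here means a weaker inhibitor, a lower number a stronger inhibitor.
Compound 2 `COc1cc(-c2nc3ccc(C)cn3c2NC2CCCCC2)ccc1OCCCNC(=O)Nc1ccc(OC(F)(F)F)cc1` gives 116 nM in this assay.
Compound 3 `COc1cc(-c2nc3ccc(C)cn3c2NC2CCCC2)ccc1OCCCNC(=O)Nc1ccc(OC(F)(F)F)cc1` gives 473 nM in this assay.

Compound 3 shows the highest of the three numbers, though compound 1 lies within the scatter of it, and only compound 2 is clearly lower. Compound 4 `COc1cc(-c2nc3ccc(C)cn3c2NC2CCCC2)ccc1OCCCNC(=O)Nc1ccc(C(F)(F)F)cc1` differs from compound 3 in a single place: trifluoromethyl in place of trifluoromethoxy on an aromatic carbon. Among the compounds with values here, one measured step bears directly on this exchange, run in the opposite direction: a 3.8-fold lower number from compound 1 to compound 2 (0.58 log units; beyond the scatter). The other step, a 4.1-fold higher number from compound 2 to compound 3 (0.61 log units; beyond the scatter), concerns the ring on the nitrogen rather than the group exchanged here, so it says nothing about this change itself. Reversing the first exchange on the framework of compound 3, the number is expected to move the other way by a similar amount, a 3.8-fold higher number from compound 3 to compound 4 (0.58 log units; beyond the scatter), because a 3.8-fold lower number from compound 1 to compound 2 (0.58 log units; beyond the scatter) went the opposite direction. Compound 4 is therefore estimated at 1800 nM, with a range from 800 nM to 4000 nM.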

Compound 4, half-maximal inhibitory concentration: 614 nM
Compound 4: middle estimate off by 2.9-fold (0.47 log units), on the high side; measured number outside the range, below it.
By their numbers in this assay, from the lowest: compound 2; then compounds 1, 3 and 4 (each within the scatter of the next).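

With cyclopentyl on the nitrogen, trifluoromethyl in place of trifluoromethoxy gives only a 1.3-fold higher number from compound 3 to compound 4 (0.11 log units; within the scatter), so the two groups cannot be told apart on this core, and the exchange does not carry over unchanged from the cyclohexyl core: the same change on two cores in this assay, a 3.8-fold lower number (0.58 log units; beyond the scatter) from compound 1 to compound 2 and a 1.3-fold lower number (0.11 log units; within the scatter) from compound 4 to compound 3, 2.9-fold (0.46 log units) apart, beyond the scatter of two such steps. Likewise, cyclopentyl in place of cyclohexyl gives a 1.4-fold higher number from compound 1 to compound 4 (0.15 log units; within the scatter) when trifluoromethyl is on the aromatic ring, so the loss seen with trifluoromethoxy does not carry over either: the same change on two cores in this assay, a 4.1-fold higher number (0.61 log units; beyond the scatter) from compound 2 to compound 3 and a 1.4-fold higher number (0.15 log units; within the scatter) from compound 1 to compound 4, 2.9-fold (0.46 log units) apart, beyond the scatter of two such steps. The two changes therefore depend on each other, and compound 2, which combines cyclohexyl with trifluoromethoxy, stands clearly apart from both compound 1 and compound 3.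

Going by these compounds, whether this dependence extends to other groups, such as a chlorine atom on the aromatic ring or a cycloheptyl ring on the nitrogen, stays open.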